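Sulfamoylurea Piperidine Amides: Quinoline Variant of Compound 2

The source may report more compounds than this note shows. Statements on the series, on what has been measured and on what is new or still open speak of the compounds shown alone.

Three members of the series have numbers in a functional assay on the whole organism (blood) with Rattus norvegicus as the target, with stated times of 24 h and 1 h, at a dose of 5 mg/kg by the intraperitoneal route; on this read-out higher numbers stand for a stronger effect at the one dose given and lower numbers for a weaker effect. Compound 1 `COc1ccc(Cl)cc1C(=O)NCCC1CCN(S(=O)(=O)NC(=O)NN2CCCCCC2)CC1` gives 36%. Compound 2 `O=C(NC[C@@H]1C[C@@H]2C=C[C@@H]1C2)NS(=O)(=O)N1CCC(CCNC(=O)C(F)(F)F)CC1` gives 22%. Compound 3 `O=C(NC1CCCCC1)NS(=O)(=O)N1CCC(CCNC(=O)c2cscn2)CC1` gives 23%. Compound 2 holds the lowest of the three numbers; its gap to compound 3 lies within the scatter, so the two are read as level, while its gap to compound 1 lies beyond the scatter, and compound 2 stands clearly under compound 1 on this read-out.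

Compound 4 `COc1ccc2nccc(C(=O)NCCC3CCN(S(=O)(=O)NC(=O)NC[C@@H]4C[C@@H]5C=C[C@@H]4C5)CC3)c2c1` has not yet been measured. It differs from compound 2 in one place, (6-methoxyquinolin-4-yl in place of trifluoromethyl on a carbonyl carbon). Within the data shown here, no step of this kind between measured compounds is available, so its size has to be judged from the three numbers alone.

An upward step is expected from compound 2 to compound 4 in this assay, of a number 9 percentage points higher from compound 2 to compound 4 (within the scatter), only somewhat larger than the scatter, because compound 1, whose amide carbonyl also bears an aromatic ring, gives 36%, whereas compound 3, whose amide carbonyl bears a smaller aromatic ring, gives 23%, leaving the direction likely but the size uncertain. Compound 4 is estimated at 31% in this assay, within a range from 12% to 50%.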

Compound 4, a percentage reported as activity, at one dose (the size of the read-out at that dose, not a potency): 10%
Compound 4: middle estimate off by 21 percentage points, on the high side; the whole stated range lies above it.
By their numbers in this assay, from the lowest: compound 4; then compounds 2 and 3 (each within the scatter of the next); then compound 1.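

In this assay, 6-methoxyquinolin-4-yl in place of trifluoromethyl on a carbonyl carbon whose other neighbours are an amide-type nitrogen gives a number 12 percentage points lower from compound 2 to compound 4 (beyond the scatter). Among these compounds, this is the first one-place comparison, and it shows that the read-out responds to a change at this position, with the group of 12 heavy atoms and two aromatic rings giving the lower number of the pair. Nothing measured on this pair or elsewhere in the series accounts for the drop, so the step stands as an observation without an explanation.

With a single step at this position, the compounds shown cannot separate the contributions of the methoxy group, the ring nitrogen and the second aromatic ring; a plain phenyl, an unsubstituted quinolin-4-yl or a simple methyl on the same carbonyl carbon would each address a different part of that question. Also open, on these data alone, is whether a step of this direction and size would recur with a different group elsewhere on the shared core, as this pair offers only one background.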